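The compounds below may be only part of what the source reports. "The series", "measured", "known", "first", "only" and "open" are said of these compounds alone.

Working notes on the series.

Compound 1 `[O-][S+](CCC(F)=C(F)F)c1ncc(-c2ccncc2)s1` is the reference point. In a functional assay on SH-SY5Y cells (Homo sapiens) for cytotoxicity, read by MTT assay, with a stated time of 48 h (a higher number here means a weaker inhibitor, a lower number a stronger inhibitor), compound 1 gives > 120000 nM, which is a limit of the assay rather than a number. Compound 2 `FC(F)(Cl)C(F)(Cl)CCSc1nc2ccc(Cl)cc2s1` gives > 120000 nM in this assay, again a limit. Compound 3 `FC(F)=C(F)CCSc1nc2ccccc2o1` likewise gives > 120000 nM in this assay, a limit. Across the measured set there is thus no numerical spread at all, only (the limit of > 120000 nM in this assay, at which 3 of the 3 values shown sit).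

Compound 4 `[O-][S+](CCC(F)=C(F)F)c1nccs1` is not yet measured. It differs from compound 1 by hydrogen in place of pyridin-4-yl on an aromatic carbon. With every measured value sitting at the limit, no step beyond the scatter is expected: the step from compound 1 to compound 4 is estimated as a step that the limit leaves unreadable from compound 1 to compound 4. Compound 4 is expected at 150000 nM, within 60000 nM to 500000 nM, most likely reported again as a limit.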

Compound 4, half-maximal inhibitory concentration: > 120000 nM
Compound 4 gave a limit, no number; the forecaster's own chance of this, stated with the estimate: 85%; the middle value does not contradict the limit.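

No step can be read between compound 1 and compound 4, as both give only a limit in this assay: the limit of > 120000 nM in this assay, at which 4 of the 4 values shown sit.

The compounds shown leave open whether any change to this series yields a measurable number.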